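This account rests on a few compounds, and the source may have more. Where it says the series, first, only, none or still open, it means among the compounds named here.

Working notes, series in a functional assay on HeLa cells (Homo sapiens) for antiproliferative activity, read by MTT assay, with a stated time of 48 h; on this read-out lower numbers stand for stronger inhibition and higher numbers for weaker inhibition:

- compound 1 `COc1ccc(-c2cc3c(cn2)n(C(C)C)c(=O)n3-c2cc(OC)c(OC)c(OC)c2)cc1O`: 4240 nM
- compound 2 `COc1ccc(-c2cc3c(cn2)n(C2CC2)c(=O)n3-c2cc(OC)c(OC)c(OC)c2)cc1O`: > 20000 nM (a limit)
- compound 3 `COc1ccc(-c2cc3c(cn2)n(CC(N)=O)c(=O)n3-c2cc(OC)c(OC)c(OC)c2)cc1O`: not yet measured

Compound 2 gives > 20000 nM, which is a limit of the assay and not a number. Its standing is known from one side only: the limit of > 20000 nM in this assay, at which 1 of the 2 values shown sits.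

The next change puts carbamoylmethyl in place of cyclopropyl on an aromatic nitrogen of the five-membered aromatic ring: carbamoylmethyl in place of cyclopropyl on an aromatic nitrogen.

Among the measured compounds shown here, only one measured step changes the group at this place: an at least 4.7-fold higher number from compound 1 to compound 2 (0.67 log units; beyond the scatter). For the measured compounds named here, it shows that this assay responds to a swap at this nitrogen, but no measured compound carries carbamoylmethyl, so its size is only a loose guide. Going by the values given here, with compound 1 at 4240 nM as the only true number, a modest step towards a lower number is expected. Compound 3 may well return only a limit. The expected step is an at least 1.6-fold lower number from compound 2 to compound 3 (0.22 log units; that floor lies within the scatter). For compound 3 the estimated value is 12000 nM, with an expected range of 3000 nM to 40000 nM.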

Compound 3, half-maximal inhibitory concentration: > 20000 nM
Compound 3: no number, only a limit (the forecaster's own chance of this, stated with the estimate: 45%); middle value at least 1.6-fold (0.22 log units) from the limit.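

In this assay, carbamoylmethyl in place of isopropyl on the aromatic nitrogen gives an at least 4.7-fold higher number from compound 1 to compound 3 (0.67 log units; beyond the scatter). Compound 3 gives > 20000 nM, which is a limit of the assay and not a number; the step between compound 2 and compound 3 cannot be read, since both values are limits. Cyclopropyl, a three-membered ring of carbon only, and carbamoylmethyl, an open group with a hydrogen-bond donor and a hydrogen-bond acceptor, both end at the same limit, so isopropyl remains the only group at this nitrogen with a true number, and the series now sits mostly on one side of the read-out: the limit of > 20000 nM in this assay, at which 2 of the 3 values shown sit.

From the compounds shown here alone, it remains open whether any group at this nitrogen gives a lower number than compound 1, for instance an ethyl or a tert-butyl group, or a longer carbon chain. Going by these compounds, it is also open whether an amine or a carboxylic acid at the end of such a chain would bring the series back within the range of the assay.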